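Alkyne to Fluorophenyl Triazole on a Terpenoid Ester

The source may hold more compounds than are shown below. What is called first, only, known or untested is meant among the compounds shown, and "the series" means these compounds.

Measured compounds:
- compound 1, `C#CCOC(=O)/C(C)=C/CC/C(C)=C/CC/C(C)=C/CC[C@@H]1[C@@]2(C)CCC(=O)C(C)(C)[C@H]2CC[C@@]1(C)O`: 46100 nM
- compound 2, `C/C(=C\CC/C(C)=C/CC[C@@H]1[C@@]2(C)CCC(=O)C(C)(C)[C@H]2CC[C@@]1(C)O)CC/C=C(\C)C(=O)OCc1cn([C@@H]2C[C@@H](n3cc(C)c(=O)[nH]c3=O)O[C@H]2CO)nn1`: 13800 nM

Both compounds share the same core and were tested in a functional assay on DU-145 cells (Homo sapiens) for antiproliferative activity, read by MTT assay, with a stated time of 48 h; on this read-out higher numbers stand for weaker inhibition and lower numbers for stronger inhibition. Compound 1 gives the highest of the two numbers, with compound 2 giving 13800 nM, the nearer of the pair; that gap lies beyond the scatter. Compound 3, `C/C(=C\CC/C(C)=C/CC[C@@H]1[C@@]2(C)CCC(=O)C(C)(C)[C@H]2CC[C@@]1(C)O)CC/C=C(\C)C(=O)OCc1cn(-c2ccccc2F)nn1`, has not yet been measured in this assay. It differs from compound 1 by 1-(2-fluorophenyl)-1H-1,2,3-triazol-4-yl in place of ethynyl on a saturated chain carbon bound to an oxygen next to a carbonyl group. Among the compounds with values here, compound 2 shows that attaching a substituted 1,2,3-triazol-4-yl at this same chain position goes with a lower number than compound 1 gives, which is the only guide available. On that basis the expected step of a 2.6-fold lower number from compound 1 to compound 3 (0.41 log units; beyond the scatter) is toward a lower number, of a size that clears the scatter. Compound 3 is therefore estimated at 18000 nM, with a range from 6000 nM to 50000 nM.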

Compound 3, half-maximal inhibitory concentration: > 150000 nM
Compound 3: no number, only a limit; the forecaster's own chance of this, stated with the estimate: 10%; middle value at least 8.3-fold (0.92 log units) away from the limit.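

In this assay, 1-(2-fluorophenyl)-1H-1,2,3-triazol-4-yl in place of ethynyl on a saturated chain carbon bound to an oxygen next to a carbonyl group gives an at least 3.2-fold higher number from compound 1 to compound 3 (0.51 log units; beyond the scatter), so this change goes with weaker inhibition. The reading for compound 3 is a limit of the assay and not a number: the limit of > 150000 nM in this assay, at which 1 of the 3 values shown sits. Compound 2 alone had linked a substituted 1,2,3-triazol-4-yl at this position to a lower number than compound 1, but compound 3 goes against that pattern, so the result here depends on what the triazole carries and not on the triazole alone.

The compounds shown leave open whether the fluorine plays any part, as a triazole bearing an unsubstituted phenyl or a benzyl group would tell. Going by these compounds, the full size of the step also stays open, with only a limit in hand.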